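Swapping a thioether chain for a small amide

The compounds below may be only part of what the source reports. "The series", "measured", "known", "first", "only" and "open" are said of these compounds alone.

Within the data shown here, compound 2 `O=C1O[C@@H](CSc2cccs2)CN1c1ccc(-n2cc(-c3ccccn3)cn2)c(F)c1` stands at the top of the two numbers so far in a physicochemical assay for lipophilicity, read by HPLC, measured as octanol-water partition (a lower number here means a more polar compound, a higher number a more lipophilic compound), where compound 2 gives 4.29. Its nearest measured neighbour is compound 1 `O=C1CNC(=O)N1C[C@H]1CN(c2ccc(-n3cc(-c4ccccn4)cn3)c(F)c2)C(=O)O1`, which in this assay gives 1.25. Among the measured compounds shown here, the one step between them, a number 3.04 log units higher from compound 1 to compound 2 (beyond the scatter), shows how strongly this part of the shared core sets the read-out.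

Compound 3 `CNC(=O)[C@H]1CN(c2ccc(-n3cc(-c4ccccn4)cn3)c(F)c2)C(=O)O1` differs from compound 2 at the same region: methylcarbamoyl in place of ((thiophen-2-yl)sulfanyl)methyl on a saturated ring carbon. The group that enters carries a hydrogen-bond donor, as the 2,5-dioxoimidazolidin-1-yl of compound 1 does, and the chain with its five-membered aromatic ring leaves. For the measured compounds named here, the step from compound 1 to compound 2 is the only measured guide, and it was large, so a large step in the opposite direction is expected here in this assay, though not necessarily of the same size, since the entering group is not the one found in compound 1.

The expected step is a number 2.89 log units lower from compound 2 to compound 3 (beyond the scatter). For compound 3 the estimate in this assay is 1.4, within a range from 0.8 to 2.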

Compound 3, partition coefficient: 1.39
Compound 3: middle estimate off by 0.01 log units, on the high side; measured number inside the range.
By their numbers in this assay, from the lowest: compounds 1 and 3 (each within the scatter of the next); then compound 2.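

Placing methylcarbamoyl on this saturated ring carbon gives a number 2.90 log units lower from compound 2 to compound 3 (beyond the scatter) in this assay and so shows that the low level seen with compound 1 is not tied to one particular group: a second, different group reaches it too. Methylcarbamoyl has no ring while (2,5-dioxoimidazolidin-1-yl)methyl has one, yet swapping one for the other gives a number 0.14 log units higher from compound 1 to compound 3 (within the scatter) and so, at this position, a low number does not depend on that ring. Nothing among the available data explains why these two groups read alike or why ((thiophen-2-yl)sulfanyl)methyl stands so far from them.

As far as these compounds go, what remains open is which part of the ((thiophen-2-yl)sulfanyl)methyl group carries the high number, a question that a plain butyl chain or a phenylsulfanylmethyl group at this position would bear on. From the compounds shown here alone, it is also open whether the amide hydrogen of methylcarbamoyl matters here, which a dimethylcarbamoyl group would address, and how far the read-out would move with a carboxylic acid or an amine in the same place.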